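The source may report more compounds than this note shows. Statements on the series, on what has been measured and on what is new or still open speak of the compounds shown alone.

Measured in a functional assay on M21 cells (Homo sapiens) for antiproliferative activity, read by sulforhodamine B assay, with a stated time of 48 h; on this read-out lower numbers stand for stronger inhibition and higher numbers for weaker inhibition:
- compound 1 `Cc1ccc(NS(=O)(=O)c2ccc(N3CCNC3=O)cc2)cc1` gives 260 nM
- compound 2 `CCc1ccc(NS(=O)(=O)c2ccc(N3CCNC3=O)cc2)cc1` gives 480 nM
- compound 3 `CCc1cccc(NS(=O)(=O)c2ccc(N3CCNC3=O)cc2)c1` gives 82 nM

Compound 2 cannot be told apart from compound 1 on these numbers, as the step between them is a 1.8-fold higher number from compound 1 to compound 2 (0.27 log units; within the scatter). Compound 3 stands clearly apart from it, with a 5.9-fold lower number from compound 2 to compound 3 (0.77 log units; beyond the scatter).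

The next compound is compound 4 `CCCCOc1ccc(NS(=O)(=O)c2ccc(N3CCNC3=O)cc2)cc1`, and its difference from compound 2 is butoxy in place of ethyl on an aromatic carbon.

The closest evidence is the change from methyl to ethyl, which gave a 1.8-fold higher number from compound 1 to compound 2 (0.27 log units; within the scatter) and so made no clear difference. The larger steps, a 5.9-fold lower number from compound 2 to compound 3 (0.77 log units; beyond the scatter) and a 3.2-fold lower number from compound 1 to compound 3 (0.50 log units; beyond the scatter), both involve 3-ethylphenyl, a change that compound 4 does not make. They therefore bear on it only weakly. Going by the values given here, no measured compound carries butoxy, so this comparison stretches the data and the uncertainty is wide.

With these steps in mind, no change beyond the scatter is expected, with a slight lean towards a higher number in this assay. The expected step is a 1.3-fold higher number from compound 2 to compound 4 (0.10 log units; within the scatter). The estimate for compound 4 is 600 nM, with an expected range from 180 nM to 2000 nM.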

Compound 4, half-maximal inhibitory concentration: 580 nM
For compound 4 the middle estimate is 1.0-fold (0.01 log units) above the measured one; the range from low to high includes it.
By their numbers in this assay, from the lowest: compound 3; then compounds 1, 2 and 4 (each within the scatter of the next, the first and the last beyond it).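

In this assay, butoxy brings more heavy atoms than ethyl and a hydrogen-bond acceptor that ethyl lacks, yet on this aromatic carbon, para to a large group, the swap gives a 1.2-fold higher number from compound 2 to compound 4 (0.08 log units; within the scatter) and so no clear change. Set against the smaller methyl, butoxy does separate from the scatter, with a 2.2-fold higher number from compound 1 to compound 4 (0.35 log units; beyond the scatter) as a modest step, so across these three compounds the chain can grow considerably at this place while the number moves only a little and never falls. No measurement available here accounts for this small response.

Going by these compounds, compound 3 shows that moving ethyl to another ring place can matter more than changing the group at this one, but whether butoxy would behave the same way in the 3-substituted arrangement remains open. On these data alone, it is also open whether this tolerance holds for groups of a different kind at the same aromatic carbon, such as an amine or a carboxylic acid, or for an alkoxy chain longer than butoxy.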